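Cytotoxicity notes: cyclohexyl to trifluoromethylphenyl on the shared core

This account rests on a few compounds, and the source may have more. Where it says the series, first, only, none or still open, it means among the compounds named here.

Compound 2 `CO[C@@H]1[C@@H](OC)[C@H](c2ccccc2)O[C@@H]2CO[C@@H](C3CCCCC3)O[C@@H]12` holds the lowest of the two numbers in a functional assay on HEL cells (Homo sapiens) for cytotoxicity; a higher number here means that more compound is tolerated, a lower number that less compound is tolerated: compound 2 gives 20 ug/mL, whereas compound 1 `O=[N+]([O-])c1ccc([C@@H]2OC[C@H]3O[C@@H](c4ccccc4)[C@H](O)[C@@H](O)[C@@H]3O2)cc1` gives 50 ug/mL, a higher number beyond the scatter. Compound 3 `CO[C@@H]1[C@@H](OC)[C@H](c2ccccc2)O[C@@H]2CO[C@@H](c3ccc(C(F)(F)F)cc3)O[C@@H]12` is not yet measured; it differs from compound 2 by 4-(trifluoromethyl)phenyl in place of cyclohexyl on a saturated ring carbon. For the measured compounds named here, no step between measured compounds differing in one place is available, so the size of this step is unknown. A modest rise is expected, and the estimated step of a 1.5-fold higher number from compound 2 to compound 3 (0.18 log units; within the scatter) leans toward the number of compound 1, 50 ug/mL. Compound 3 is expected to give 30 ug/mL, within 10 ug/mL to 100 ug/mL.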

Compound 3, minimum cytotoxic concentration: >= 16 ug/mL
Compound 3: a limit, no number; the forecaster's own chance of this, stated with the estimate: 10%; the middle value lies beyond the limit too.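

For the compounds shown here, compound 3 gives >= 16 ug/mL in this assay, which is a limit and not a number, and no step from compound 2 to compound 3 can be read. From the compounds shown here alone, whether 4-(trifluoromethyl)phenyl in place of cyclohexyl raises or lowers the tolerated concentration remains open.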